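The source may report more compounds than this note shows. Statements on the series, on what has been measured and on what is new or still open speak of the compounds shown alone.

Compound 3, `COc1ccccc1-c1ccc(S(=O)(=O)N2CCC(N3CCC(C)CC3)CC2)cc1`, stands at a limit of the assay rather than at a number. In an ADME assay on HCT-116 cells (Homo sapiens) for cytotoxicity, read by CellTiter-Glo, with a stated time of 72 h (a lower number here means a stronger inhibitor, a higher number a weaker inhibitor), compound 3 gives > 5000 nM, which is a limit. The two other compounds shown stand the same way. Compound 1, `CC1CCN(C2CCN(S(=O)(=O)c3cccc(Br)c3)CC2)CC1`, gives > 5000 nM in this assay, also a limit. Compound 2, `CC1CCN(C2CCN(S(=O)(=O)c3cn(C)cn3)CC2)CC1`, gives > 10000 nM in this assay, again a limit. Among the measured compounds shown here, the one step between measured compounds, a step that the two limits leave unreadable from compound 1 to compound 2, is therefore unreadable. Compound 4, `COC(=O)c1ccc(S(=O)(=O)N2CCC(N3CCC(C)CC3)CC2)cc1`, differs from compound 3 by methoxycarbonyl in place of 2-methoxyphenyl on an aromatic carbon. For the measured compounds named here, no measured step with a readable size bears on this change; the limit of > 5000 nM in this assay, at which 2 of the 3 values shown sit, and the limit of > 10000 nM in this assay, at which 1 of the 3 values shown sits, show that every value here is a limit. No step beyond the scatter can be expected in this assay. Compound 4 is estimated at 10000 nM, with a range from 4000 nM to 40000 nM. The step that the limit leaves unreadable from compound 3 to compound 4 is expected to be small.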

Compound 4, half-maximal inhibitory concentration: > 5000 nM
Compound 4 was reported as a limit; the forecaster's own chance of this, stated with the estimate: 85%; the middle value lies beyond the limit too.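

Among the compounds shown here, compound 3 and compound 4 both stand at a limit in this assay, so no step between them can be read. The compounds shown leave open how strongly any of them inhibits: none has a measured number.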